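From methoxy to fluoro: one step in a small series

The compounds below may be only part of what the source reports. "The series", "measured", "known", "first", "only" and "open" are said of these compounds alone.

Three compounds measured so far in an ADME assay on HEK293 cells (Homo sapiens) for cytotoxicity, read by MTT assay, with a stated time of 72 h (a higher number here means a weaker inhibitor, a lower number a stronger inhibitor), are
compound 1 `COc1ccc(C(=O)N2CCN(CC(=O)N3CCN(CCCc4c[nH]c5ccccc45)CC3)CC2)cc1` (156000 nM)
compound 2 `O=C(CN1CCN(C(=O)c2ccc(Br)cc2)CC1)N1CCN(CCCc2c[nH]c3ccccc23)CC1` (71900 nM)
compound 3 `COc1cccc(C(=O)N2CCN(CC(=O)N3CCN(CCCc4c[nH]c5ccccc45)CC3)CC2)c1` (143000 nM)

Compound 3 gives 143000 nM in this assay and cannot be separated from either of the other two, since the data show a 1.1-fold lower number from compound 1 to compound 3 (0.04 log units; within the scatter) and also a 2.0-fold higher number from compound 2 to compound 3 (0.30 log units; within the scatter) on the same scale. Compound 4 `O=C(CN1CCN(C(=O)c2cccc(F)c2)CC1)N1CCN(CCCc2c[nH]c3ccccc23)CC1` differs from compound 3 in one place (fluoro in place of methoxy on an aromatic carbon) with fluoro in place of methoxy on an aromatic carbon, meta to a large group.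

Among the compounds with values here, no compound carrying fluoro has been measured, so the evidence is indirect. The nearest guide is a 2.2-fold lower number from compound 1 to compound 2 (0.34 log units; beyond the scatter) with bromo in place of methoxy, a modest step. The other comparison, a 1.1-fold lower number from compound 1 to compound 3 (0.04 log units; within the scatter) with 3-methoxyphenyl in place of 4-methoxyphenyl, suggests that the position of the methoxy group matters little in these three compounds. A small move toward a lower number is therefore expected, probably not beyond the scatter. The step expected is a 1.3-fold lower number from compound 3 to compound 4 (0.11 log units; within the scatter) on this reasoning. For compound 4 the estimated value is 110000 nM with an expected range from 60000 nM to 190000 nM as its upper end.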

Compound 4, half-maximal inhibitory concentration: 182000 nM
Compound 4: middle estimate off by 1.7-fold (0.22 log units), on the low side, within the range that was stated.
By their numbers in this assay, from the lowest: compounds 2, 3, 1 and 4 (each within the scatter of the next, the first and the last beyond it).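

At this position, on an aromatic carbon meta to a large group, this assay does not separate fluoro from methoxy (a 1.3-fold higher number from compound 3 to compound 4 (0.10 log units; within the scatter)), so the exchange of a two-heavy-atom group for a one-heavy-atom group leaves no readable mark. Within the data shown here, the 3-fluorophenyl group also cannot be told apart from 4-methoxyphenyl (a 1.2-fold higher number from compound 1 to compound 4 (0.07 log units; within the scatter)), while against 4-bromophenyl it gives the only new step beyond the scatter (a 2.5-fold higher number from compound 2 to compound 4 (0.40 log units; beyond the scatter)), and that step is modest. The earlier compounds had shown compound 2 apart from compound 1 alone, and now compound 2 sits apart from compound 4 as well, with compound 3 still going against any clean separation of the bromo compound from the rest.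

Nothing available explains these differences, so they stand as bare observations. On these data alone, what an amine, a carboxylic acid or a longer alkoxy chain would do on this aromatic carbon stays open, as does whether a 3-bromophenyl group would read like 4-bromophenyl.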